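Amide aryl variation at the assay ceiling

This account rests on a few compounds, and the source may have more. Where it says the series, first, only, none or still open, it means among the compounds named here.

Measured compounds:
compound 1, `Cc1ccc(NC(=O)c2cccc(/C=C3\CC(=O)N(c4ccccc4)C3=O)c2)cc1C`
compound 2, `O=C(Nc1ccc(Cl)cc1)c1cccc(/C=C2\CC(=O)N(c3ccccc3)C2=O)c1`

In an ADME assay on HCT-116 cells (Homo sapiens) for cytotoxicity, read by MTT assay, with a stated time of 72 h (on this read-out higher numbers stand for weaker inhibition and lower numbers for stronger inhibition), compound 1 gives > 100000 nM, which is a limit of the assay and not a number. Compound 2 gives > 100000 nM, again a limit and not a number. The step that the two limits leave unreadable from compound 1 to compound 2 is accordingly not readable. Compound 2 therefore stands at the limit of > 100000 nM in this assay, at which 2 of the 2 values shown sit, and has no number of its own on this read-out.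

Compound 3, `CCOc1ccc(NC(=O)c2cccc(/C=C3\CC(=O)N(c4ccccc4)C3=O)c2)cc1`, differs from compound 2 by ethoxy in place of chloro on an aromatic carbon, an ethoxy in place of chloro on an aromatic carbon. Within the data shown here, the one measured step, a step that the two limits leave unreadable from compound 1 to compound 2, concerns the same aryl group on the amide nitrogen and lies between two limits, so it gives neither a size nor a direction to carry over. With both measured compounds at the ceiling, the expected step that the limit leaves unreadable from compound 2 to compound 3 is none beyond the scatter. Compound 3 is therefore estimated at 150000 nM, with a range from 50000 nM to 500000 nM, and it is expected that this assay again reports only a limit for compound 3.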

Compound 3, half-maximal inhibitory concentration: 84800 nM
Estimate against measurement, compound 3: 1.8-fold (0.25 log units) above, within the range that was stated.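

Among these compounds, with 4-ethoxyphenyl on the amide nitrogen, compound 3 gives 84800 nM in this assay, the first actual number in this set and evidence that this aryl position can bring a compound within the measurable range. Set against the two earlier limits, the change reads as an at least 1.1-fold lower number from compound 2 to compound 3 (0.07 log units; that floor lies within the scatter), and as an at least 1.1-fold lower number from compound 1 to compound 3 (0.07 log units; that floor lies within the scatter), so neither floor establishes a change beyond the scatter, and the true size of each step stays unknown. Compound 1 and compound 2 each remain at a limit and not a number, and the step between them cannot be read: the limit of > 100000 nM in this assay, at which 2 of the 3 values shown sit.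

The compounds shown leave open how far under or over the ceiling compound 1 and compound 2 would fall if they had numbers, and so whether ethoxy in place of chloro has any real effect on this read-out. They also leave open whether the number for compound 3 depends on the oxygen or on the chain, a question that a methoxy, a propoxy or an amine on the same aromatic carbon would address.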